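This account rests on a few compounds, and the source may have more. Where it says the series, first, only, none or still open, it means among the compounds named here.

In a functional assay on HCT-116 cells (Homo sapiens) for cytotoxicity, read by MTT assay, with a stated time of 72 h (on this read-out lower numbers stand for stronger inhibition and higher numbers for weaker inhibition), two compounds built on the shared core have been measured so far. Compound 1 (`CCCCNC(=S)N/N=C1\CC(c2ccc(O)cc2)Oc2cc(O)ccc21`), with butylamino on the thiocarbonyl carbon, gives 49300 nM, and compound 2 (`CCCN(CCC)C(=S)N/N=C1\CC(c2ccc(O)cc2)Oc2cc(O)ccc21`), with dipropylamino there, gives 41900 nM. Compound 2 therefore stands level with compound 1, and neither can be set apart from the other on these numbers.

Compound 3 (`CCCNC(=S)N/N=C1\CC(c2ccc(O)cc2)Oc2cc(O)ccc21`) follows from compound 2 by hydrogen in place of propyl on an amide-type nitrogen. This puts hydrogen in place of propyl on an amide-type nitrogen, so that dipropylamino becomes propylamino. Among the measured compounds shown here, only one measured step bears on this change: a 1.2-fold lower number from compound 1 to compound 2 (0.07 log units; within the scatter), which exchanged butylamino for dipropylamino on the same thiocarbonyl carbon. That step was small, and like compound 3, compound 1 keeps a hydrogen on that nitrogen and gives 49300 nM. No step beyond the scatter is therefore expected in this assay, in either direction. The expected step is a 1.1-fold higher number from compound 2 to compound 3 (0.05 log units; within the scatter). For compound 3 the estimated value is 47000 nM, with an expected range of 26000 nM to 85000 nM.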

Compound 3, half-maximal inhibitory concentration: 54000 nM
For compound 3 the middle estimate is 1.1-fold (0.06 log units) below the measured one, within the range that was stated.
By their numbers in this assay, from the lowest: compounds 2, 1 and 3 (each within the scatter of the next).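

In this assay, among the compounds shown here, the exchange of dipropylamino for propylamino gives a 1.3-fold higher number from compound 2 to compound 3 (0.11 log units; within the scatter) and so shows that this amide-type nitrogen can carry hydrogen in place of propyl with no step that stands out from the scatter. The comparison of butylamino with propylamino, which gives a 1.1-fold higher number from compound 1 to compound 3 (0.04 log units; within the scatter), adds that shortening the chain on a nitrogen that keeps its hydrogen also leaves the number within the scatter, so that all three groups on the thiocarbonyl carbon read alike and none of them can be set apart from the others. No evidence is at hand that would account for this flat result or connect it to any property of these groups.

On these data alone, the three compounds cover only saturated chains of similar size on this nitrogen, so it remains open whether a much longer chain such as octyl, a phenyl ring, a chain ending in an amine or a carboxylic acid would move the number beyond the scatter. Also open, as far as these compounds go, is how the plain amino group, with hydrogen in place of the remaining propyl, would compare with propylamino.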